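Extending the hydroxy chain on the sulfonyl group

The source may hold more compounds than are shown below. What is called first, only, known or untested is meant among the compounds shown, and "the series" means these compounds.

Measured in a physicochemical assay for solubility, at pH 7.4 (a lower number here means a less soluble compound, a higher number a more soluble compound), so far
compound 1 `NS(=O)(=O)c1ccc(S(=O)(=O)CCCO)cc1` gives 7200 ug/mL
compound 2 `NS(=O)(=O)c1ccc(S(=O)(=O)CCO)c(F)c1` gives 3300 ug/mL

Of these two numbers, compound 2 holds the lower, and its gap to compound 1 lies beyond the scatter. Compound 3 `NS(=O)(=O)c1ccc(S(=O)(=O)CCCO)c(F)c1` is still to be measured. Its structure departs from that of compound 2 by one change, (hydroxymethyl in place of hydroxy on a saturated chain carbon, two bonds along the chain from a sulfonyl sulfur), which is hydroxymethyl in place of hydroxy on a saturated chain carbon, two bonds along the chain from a sulfonyl sulfur. Within the data shown here, no measured pair shows this change alone, so the data give no direct guide to its size. In this assay no shift beyond the scatter is expected, so the estimate stays close to compound 2 at 3300 ug/mL and leans slightly downward. The expected move is a 1.1-fold lower number from compound 2 to compound 3 (0.06 log units; within the scatter), a small one. For compound 3 the estimated value is 2900 ug/mL (expected range 1300 ug/mL to 6500 ug/mL).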

Compound 3, solubility: 6600 ug/mL
For compound 3 the middle estimate is 2.3-fold (0.36 log units) below the measured one; measured number above the stated range.
By their numbers in this assay, from the lowest: compounds 2, 3 and 1 (each within the scatter of the next, the first and the last beyond it).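

In this assay the change to hydroxymethyl in place of hydroxy, on a saturated chain carbon two bonds along the chain from a sulfonyl sulfur, now has a measured step: a 2.0-fold higher number from compound 2 to compound 3 (0.30 log units; within the scatter). Among these compounds, the series also gains a first reading for fluoro in place of hydrogen on an aromatic carbon, a 1.1-fold lower number from compound 1 to compound 3 (0.04 log units; within the scatter), with the 3-hydroxypropyl chain kept on the sulfonyl group. Neither single change therefore gives a step beyond the scatter, and nothing measured here bears on the reason for the size of either step.

From the compounds shown here alone, the fluoro step is read on the 3-hydroxypropyl chain alone, so its size on other chains remains unknown. Also open, going by these compounds, is whether in this assay a longer chain, or an amine or a carboxylic acid in place of hydroxy, gives a step beyond the scatter.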